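The compounds below may be only part of what the source reports. "The series", "measured", "known", "first", "only" and "open" are said of these compounds alone.

Of the compounds shown here, three have so far been tested in a functional assay on HCT-116 cells (Homo sapiens) for cytotoxicity, read by MTT assay, with a stated time of 48 h; on this read-out lower numbers stand for stronger inhibition of growth and higher numbers for weaker inhibition of growth. Compound 1 `Cc1nc2cc(Cl)c(Cl)cc2[nH]1` gives 51000 nM, and compound 2 `OC[C@H]1O[C@@H](n2cnc3cc(F)c(F)cc32)[C@H](O)[C@@H]1O` gives 67000 nM. Compound 3 `Cn1c(C(F)(F)F)nc2cc(Cl)c(Cl)cc21` gives 56000 nM, which places it alongside the other two. All three values lie within the usual scatter of one another, so no order can be read among them.

Compound 4 `C=CCn1c(C(F)(F)F)nc2cc(Cl)c(Cl)cc21` has not yet been measured. It keeps the core of compound 3 and turns the methyl into an allyl: vinyl in place of hydrogen on a saturated chain carbon bound to an aromatic nitrogen. Put simply, this is vinyl in place of hydrogen on a saturated chain carbon bound to an aromatic nitrogen.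

Among the measured compounds shown here, no measured pair here shows what such a change does, so the closeness of the three values is the only guide. Starting from compound 3 at 56000 nM, a small move towards a lower number is expected in this assay, probably not beyond the scatter. The estimated step of a 1.4-fold lower number from compound 3 to compound 4 (0.15 log units; within the scatter) is therefore modest. For compound 4 the expected value is 40000 nM, within an estimated range of 15000 nM to 90000 nM.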

Compound 4, concentration for 50% growth inhibition: 89200 nM
Estimate against measurement, compound 4: 2.2-fold (0.35 log units) below; the range from low to high includes it.
By their numbers in this assay, from the lowest: compounds 1, 3, 2 and 4 (each within the scatter of the next).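

Among the compounds shown here, this is the first pair in the set that differs in one place, so it gives the first direct look at this position. In this assay, putting vinyl in place of hydrogen on the saturated chain carbon bound to an aromatic nitrogen, which turns methyl into allyl, gives a 1.6-fold higher number from compound 3 to compound 4 (0.20 log units; within the scatter), and that step lies within the scatter, so the assay cannot separate this change from no change at all. Nothing available here bears on why these two compounds read so alike.

A single step at this place cannot show how far the position stays this flat. Going by these compounds, whether a longer saturated chain, a benzyl group, an amine or a carboxylic acid on this carbon would move the number beyond the scatter stays open.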